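Lengthening the Saturated Chain on a Glycosyl Thiadiazole

A few compounds are considered here, and "the series" means these few. Any claim that something is new, unique, unknown or untested is made for them only; others in the source may bear on it.

Compound 2 `CCCCCCCC(=O)Nc1nnc(S[C@@H]2O[C@H](CO)[C@H](O)[C@H](O)[C@H]2O)s1` carries a saturated chain on the shared core. In an ADME assay on CHO-K1 cells (Cricetulus griseus) for cytotoxicity, read by MTT assay, with a stated time of 24 h (a higher number here means a weaker inhibitor, a lower number a stronger inhibitor), compound 2 gives 60100 nM, the highest of the three numbers measured. Compound 1 `CCCCCCCC/C=C\CCCCCCCC(=O)Nc1nnc(S[C@@H]2O[C@H](COC(C)=O)[C@H](OC(C)=O)[C@H](OC(C)=O)[C@H]2OC(C)=O)s1` gives 26300 nM and compound 3 `CCCCCCCC/C=C\CCCCCCCCCCCC(=O)Nc1nnc(S[C@@H]2O[C@H](COC(C)=O)[C@H](OC(C)=O)[C@H](OC(C)=O)[C@H]2OC(C)=O)s1` gives 25200 nM; both lie beyond the scatter below compound 2, so compound 2 is the weakest inhibitor here. Compound 4 `CCCCCCCCCC(=O)Nc1nnc(S[C@@H]2O[C@H](CO)[C@H](O)[C@H](O)[C@H]2O)s1` has not yet been measured. It differs from compound 2 in one place: ethyl in place of hydrogen on a saturated chain carbon, seven bonds along the chain from a carbonyl carbon. For the measured compounds named here, no measured pair shows this exact change. Since compound 1 gives 26300 nM and compound 3 gives 25200 nM with longer chains, a longer chain is expected to lower the number a little. The expected step is a 1.3-fold lower number from compound 2 to compound 4 (0.13 log units; within the scatter), possibly within the scatter. Compound 4 is estimated at 45000 nM, between 25000 nM and 90000 nM.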

Compound 4, half-maximal inhibitory concentration: "not active" (no number reported)
Compound 4 has no reported number here; there is nothing to compare the estimate with.
By their numbers in this assay, from the lowest: compounds 3 and 1 (each within the scatter of the next); then compound 2.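

For the compounds shown here, compound 4 has no number in this assay, so no step from compound 2 to compound 4 can be read. No measurement here accounts for this result. As far as these compounds go, whether ethyl in place of hydrogen on this chain shifts the number stays open.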